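A ring swap at the solubility limit

This account rests on a few compounds, and the source may have more. Where it says the series, first, only, none or still open, it means among the compounds named here.

Measured in a physicochemical assay for solubility; a lower number here means a less soluble compound, a higher number a more soluble compound:
- compound 1 `COc1cc(/C=C(/SCc2ccc(Br)cc2)C(=O)c2ccc(C(=O)O)cc2)ccc1F`: < 1000 ug/mL
- compound 2 `O=C(O)c1ccc(C(=O)/C(=C\c2ccc(Br)c([N+](=O)[O-])c2)SCc2ccc(Cl)cc2)cc1`: < 1000 ug/mL
- compound 3 `O=C(O)c1ccc(C(=O)/C(=C\c2ccc(F)c([N+](=O)[O-])c2)SCc2ccc(C(F)(F)F)cc2)cc1`: < 1000 ug/mL

Compound 1 gives only a limit, < 1000 ug/mL, and not a number. The other two readings offer no number either, so the series holds just (the limit of < 1000 ug/mL in this assay, at which 3 of the 3 values shown sit). Compound 4 `O=C(O)c1ccc(C(=O)/C(=C\c2ccc([N+](=O)[O-])c(F)c2)SCc2ccc(Br)cc2)cc1` has not been measured yet. It differs from compound 1 in one place: 3-fluoro-4-nitrophenyl in place of 4-fluoro-3-methoxyphenyl on a double-bonded chain carbon bound to a double-bonded chain carbon. In words, 3-fluoro-4-nitrophenyl stands in place of 4-fluoro-3-methoxyphenyl on a double-bonded chain carbon bound to a double-bonded chain carbon. For the measured compounds named here, no step between measured compounds exists, so no step beyond the scatter is expected in this assay, in either direction, for compound 1 because of the limit of < 1000 ug/mL in this assay, at which 3 of the 3 values shown sit. The expected step is a step that the limit leaves unreadable from compound 1 to compound 4. Compound 4 is estimated at 500 ug/mL, with an expected range of 100 ug/mL to 1000 ug/mL.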

Compound 4, solubility: < 1000 ug/mL
Compound 4: no number, only a limit; the forecaster's own chance of this, stated with the estimate: 85%; the middle value lies beyond the limit too.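

No step can be read from compound 1 to compound 4, because this assay gives only a limit for both: the limit of < 1000 ug/mL in this assay, at which 4 of the 4 values shown sit.

The compounds shown leave open the actual solubility of each one and whether 3-fluoro-4-nitrophenyl in place of 4-fluoro-3-methoxyphenyl alters it.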